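The compounds below may be only part of what the source reports. "The series", "measured", "known", "first", "only" and "open" are said of these compounds alone.

Measured so far in a functional assay on HepG2 cells (Homo sapiens) for antiproliferative activity, read by sulforhodamine B assay, with a stated time of 48 h; a higher number here means a weaker inhibitor, a lower number a stronger inhibitor:

- compound 1 `COc1cccc(C(=O)C2OC2c2ccc(F)cc2)c1`: 17 nM
- compound 2 `COc1ccc(C2=CC(c3ccc(Br)cc3)NC(=S)N2)cc1`: 30 nM
- compound 3 `COc1cccc(C2=NNC(c3ccc(Cl)cc3)C2O)c1`: 35.3 nM

Within the data shown here, three compounds with three different cores, so no single-point steps between measured compounds are available; the numbers can only be compared as they stand. Compound 3 has the highest number of the three. Its nearest neighbour is compound 2, whose number is lower by an amount within the scatter, so the two cannot be told apart in this assay. Compound 1 stands furthest away, with a number lower than that of compound 3 by a margin beyond the scatter.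

Compound 4 `COc1cccc(C2=NNC(c3ccc(Br)cc3)C2O)c1` keeps the core of compound 3 and changes one substituent: bromo in place of chloro on an aromatic carbon. The exchange leaves the count of heavy atoms, donors and acceptors unchanged and touches no ring. Nothing in the measured set shows what such a swap does in this assay, so no direction is assumed; the expected step is small, none beyond the scatter.

On that basis the value of compound 4 in this assay is estimated at 35 nM, with a range from 17 nM to 72 nM, which corresponds to an expected step of a 1.0-fold lower number from compound 3 to compound 4 (0.00 log units; within the scatter).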

Compound 4, half-maximal inhibitory concentration: 43 nM
Compound 4: middle estimate off by 1.2-fold (0.09 log units), on the low side; the range from low to high includes it.
By their numbers in this assay, from the lowest: compounds 1, 2, 3 and 4 (each within the scatter of the next, the first and the last beyond it).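

In this assay, among these compounds, the exchange of chloro for bromo on an aromatic carbon, para to a large group, gives a 1.2-fold higher number from compound 3 to compound 4 (0.09 log units; within the scatter) as the first single-place step. The 4-chlorophenyl and 4-bromophenyl forms of the shared core therefore cannot be told apart in this assay, a reading that rests on this one pair and is not a rule for the position. No measurement at hand bears on why the two halogens read alike, and none is offered here.

Still open, going by these compounds, is how far this position stays silent once the group on that carbon is no longer chloro or bromo: an amine, a carboxylic acid, a methoxy group or a longer chain there would test this on the shared core of compound 3 and compound 4. Also open, on these data alone, is whether the same exchange reads alike on other cores, such as the core of compound 1, which carries a fluoro group, or that of compound 2, which carries a bromo group.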